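A few compounds are considered here, and "the series" means these few. Any claim that something is new, unique, unknown or untested is made for them only; others in the source may bear on it.

Compound 3 `Cc1ncc(-c2nc(C(F)(F)F)sc2N2CCN(C(=O)Cn3nc(C)nc3C)[C@H](C)C2)cn1` gives 578 nM in a functional assay on U2OS cells for antagonist activity at C-X-C chemokine receptor type 3 (Homo sapiens), read by beta-arrestin recruitment (on this read-out higher numbers stand for weaker inhibition and lower numbers for stronger inhibition), and stands highest of the three numbers recorded. Compound 2 `Cc1ncc(-c2nc(C(F)(F)F)sc2N2CCN(C(=O)Cn3cnc4cccnc43)[C@H](C)C2)cn1` gives 168 nM and compound 1 `C[C@@H]1CN(c2sc(Br)nc2-c2nc3ccccc3[nH]2)CCN1C(=O)Cn1cnc2cccnc21` gives 126 nM in this assay. Within the data shown here, the only single-site step so far is a 3.4-fold higher number from compound 2 to compound 3 (0.54 log units; beyond the scatter), which concerns the group on the chain carbon bound to the carbonyl, not the aryl group on the shared core. Compound 4 `CCOc1ccc(-c2nc(C(F)(F)F)sc2N2CCN(C(=O)Cn3nc(C)nc3C)[C@H](C)C2)cn1` differs from compound 3 as follows: 6-ethoxypyridin-3-yl in place of 2-methylpyrimidin-5-yl on an aromatic carbon. Among the measured compounds shown here, no measured pair varies this aryl group alone; compound 1 carries different groups at two places, so its gap to compound 3 cannot be assigned to one change. For the measured compounds named here, with no step bearing on the change, no shift beyond the scatter is expected in this assay in either direction, and the number for compound 4 is expected near that of compound 3. Compound 4 is estimated at 450 nM in this assay, within 150 nM to 1400 nM, which means an expected step of a 1.3-fold lower number from compound 3 to compound 4 (0.11 log units; within the scatter).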

Compound 4, half-maximal inhibitory concentration: 505 nM
The estimate for compound 4 lay 1.1-fold (0.05 log units) below the measured number; low and high end bracket the measured number.
By their numbers in this assay, from the lowest: compounds 1 and 2 (each within the scatter of the next); then compounds 4 and 3 (each within the scatter of the next).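

In this assay, among these compounds, 6-ethoxypyridin-3-yl in place of 2-methylpyrimidin-5-yl gives a 1.1-fold lower number from compound 3 to compound 4 (0.06 log units; within the scatter) with the group on the chain carbon bound to the carbonyl held constant, the first reading of this aryl position on its own. On this aromatic carbon next to the ring nitrogen, a group of 9 heavy atoms with 1 ring hetero atom and an ethoxy chain thus reads the same as a group of 7 heavy atoms with 2 ring hetero atoms, within the scatter. Nothing available bears on why the number holds.

From the compounds shown here alone, whether the same holds with the larger group on the chain carbon of compound 2 168 nM remains open. Also open, going by these compounds, is how an amine, a carboxylic acid or a longer alkoxy chain on this aryl ring would read.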